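From a Benzoxazole Chain to a Thiadiazole in Compound 3

The source may hold more compounds than are shown below. What is called first, only, known or untested is meant among the compounds shown, and "the series" means these compounds.

In a functional assay on PC-3 cells (Homo sapiens) for antiproliferative activity, read by MTT assay, with a stated time of 48 h (a lower number here means a stronger inhibitor, a higher number a weaker inhibitor), compound 1 (`COc1ccc(CN(C(=O)CSC2=CN=NC2C)c2cc(OC)c(OC)c(OC)c2)cc1`) gives 45000 nM and compound 2 (`COc1ccc(CN(C(=O)CCCSc2nc3ccccc3o2)c2cc(OC)c(OC)c(OC)c2)cc1`) gives 32700 nM, so compound 2 stands within the scatter of compound 1. Compound 3 (`COc1ccc(CN(C(=O)CSc2nncs2)c2cc(OC)c(OC)c(OC)c2)cc1`) differs from compound 2 by (1,3,4-thiadiazol-2-yl)sulfanyl in place of 2-((1,3-benzoxazol-2-yl)sulfanyl)ethyl on a saturated chain carbon bound to a carbonyl carbon. Within the data shown here, only one measured step bears on this change, a 1.4-fold lower number from compound 1 to compound 2 (0.14 log units; within the scatter), which replaced a group at the same kind of place. A move beyond the scatter is therefore not expected in this assay. The estimated step is a 1.1-fold higher number from compound 2 to compound 3 (0.03 log units; within the scatter), with no clear direction expected. For compound 3 the estimated value is 35000 nM, with an expected range of 13000 nM to 90000 nM.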

Compound 3, half-maximal inhibitory concentration: 5530 nM
Beside the measured number, compound 3's estimate is 6.3-fold (0.80 log units) above it; the measured number lies below the stated range.
By their numbers in this assay, from the lowest: compound 3; then compounds 2 and 1 (each within the scatter of the next).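

In this assay, this position proved able to move the number beyond the scatter, which the earlier pair had not shown: the change to (1,3,4-thiadiazol-2-yl)sulfanyl gave a 5.9-fold lower number from compound 2 to compound 3 (0.77 log units; beyond the scatter). A change on the sulfur alone also went beyond the scatter, with an 8.1-fold lower number from compound 1 to compound 3 (0.91 log units; beyond the scatter). Nothing available explains either step. The compounds shown leave open how much of the first step belongs to the shorter chain and how much to the change of ring, as both differ together. As far as these compounds go, how an amine on the thiadiazole ring would read also remains open.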